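One Chain Stereocentre Inverted in a Methoxy-Bearing Compound

A few compounds are considered here, and "the series" means these few. Any claim that something is new, unique, unknown or untested is made for them only; others in the source may bear on it.

- compound 1 `CCCC[C@](C)(OC)[C@@H](O)/C=C/C1[C@H](O)CC(=O)[C@@H]1C/C=C\CCCC(=O)OC`: 0.912 mg/kg
- compound 2 `CCCC[C@](C)(OC)[C@H](O)/C=C/C1[C@H](O)C[C@H](O)[C@@H]1C/C=C\CCCC(=O)OC`: 1.82 mg/kg
- compound 3 `CCCC[C@@](C)(OC)[C@H](O)/C=C/C1[C@H](O)C[C@H](O)[C@@H]1C/C=C\CCCC(=O)OC`: 0.888 mg/kg

In a functional assay on the whole organism with Mus musculus as the target (on this read-out lower numbers stand for an effect already at smaller amounts and higher numbers for an effect only at larger amounts of compound), compound 1 gives 0.912 mg/kg. This value lies within the scatter of both compound 2 and compound 3, even though those two differ from each other by more than the scatter.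

Compound 4 `CCCC[C@](C)(OC)[C@H](O)/C=C/C1[C@H](O)CC(=O)[C@@H]1C/C=C\CCCC(=O)OC` is the mirror-image arrangement of compound 1 at one centre: the two compounds have the same atoms and bonds; at least one stereo element is drawn with a configuration in one of them and without one in the other: 1 of 7 stereo elements differ; a stereocentre at a saturated chain carbon is drawn S in compound 1 and R in compound 4. Its atoms and bonds are unchanged.

For the measured compounds named here, the only measured change of this kind is a 2.0-fold lower number from compound 2 to compound 3 (0.31 log units; beyond the scatter). It was modest, but it inverts a different saturated chain carbon, and compounds 2 and 3 also differ from compound 1 elsewhere. Its size is therefore a rough guide, and its direction does not carry over.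

The expected result is no change beyond the scatter, shown as a 1.1-fold lower number from compound 1 to compound 4 (0.06 log units; within the scatter), though a real shift either way remains possible. For compound 4 the estimated value is 0.8 mg/kg, with an expected range from 0.2 mg/kg to 3 mg/kg.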

Compound 4, dose for half-maximal effect: 0.479 mg/kg
Compound 4: middle estimate off by 1.7-fold (0.22 log units), on the high side; measured number inside the range.
By their numbers in this assay, from the lowest: compounds 4, 3, 1 and 2 (each within the scatter of the next, the first and the last beyond it).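

For the compounds shown here, this is the first reading at this saturated chain carbon: inverting it gives a 1.9-fold lower number from compound 1 to compound 4 (0.28 log units; within the scatter) in this assay, so this read-out does not separate the two arrangements here. The other inversion shown, at a different saturated chain carbon, gives a 2.0-fold lower number from compound 2 to compound 3 (0.31 log units; beyond the scatter), which suggests that inverting one carbon need not count equally at every place, although compounds 2 and 3 also differ from compound 1 elsewhere. The comparison itself rests on a single fact about the drawn structures: the fact that one of compounds 1 and 4 is drawn with a defined configuration and the other without, at the place where they differ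

The compounds shown do not tell whether this inversion would stay within the scatter with a hydroxyl in place of the carbonyl. They also leave open whether it would do so with a free carboxylic acid in place of the methyl ester.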